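A few compounds are considered here, and "the series" means these few. Any claim that something is new, unique, unknown or untested is made for them only; others in the source may bear on it.

Measured so far:
Compound 1 `COC(=O)[C@@]1(C)CCC=C2[C@@H]1CC[C@@H](C)[C@]2(C)Cc1c[nH]c2ccc(C(F)(F)F)cc12` gives 15000 nM in a functional assay on HBL-100 cells (Homo sapiens) for inhibition, read by sulforhodamine B assay, with a stated time of 48 h; a higher number here means a weaker inhibitor of growth, a lower number a stronger inhibitor of growth.
Compound 2 `COC(=O)[C@@]1(C)CCC=C2[C@@H]1CC[C@@H](C)[C@]2(C)Cc1c(C)[nH]c2ccc(C(F)(F)F)cc12` gives 16000 nM.
Compound 3 `COC(=O)[C@@]1(C)CC[C@@H]2C3=C1CC[C@@H](C)[C@]3(C)Cc1c2[nH]c2c(C)cccc12` gives 13000 nM.

Compound 3 holds the lowest of the three numbers, yet its gaps to compound 1 and to compound 2 both sit within the scatter, so no order among the three can be read. Compound 4 `COC(=O)[C@@]1(C)CC[C@@H]2C3=C1CC[C@@H](C)[C@]3(C)Cc1c2[nH]c2c(Cl)cccc12` differs from compound 3 by chloro in place of methyl on an aromatic carbon. Among the measured compounds shown here, only one measured step bears on such a swap on an aromatic carbon: a 1.1-fold higher number from compound 1 to compound 2 (0.03 log units; within the scatter), which barely moved the number. For the measured compounds named here, no measured pair exchanges methyl for chloro, so the expectation rests on that single step and on the tight cluster of values. The step from compound 3 to compound 4 is expected to be no change at the digits printed from compound 3 to compound 4 (within the scatter), none beyond the scatter. Compound 4 is estimated at 13000 nM, with a range from 6000 nM to 28000 nM.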

Compound 4, concentration for 50% growth inhibition: 16000 nM
The estimate for compound 4 lay 1.2-fold (0.09 log units) below the measured number; measured number inside the range.
By their numbers in this assay, from the lowest: compounds 3, 1, 2 and 4 (each within the scatter of the next).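

On this aromatic carbon, ortho to a fused ring, chloro in place of methyl gives a 1.2-fold higher number from compound 3 to compound 4 (0.09 log units; within the scatter) in this assay. Among the compounds shown here, this is the first measured exchange at this position, and the earlier step, on a different carbon of a different core, could not speak for it: here, methyl and chloro give values that cannot be told apart. Nothing measured gives a reason for this result.

From the compounds shown here alone, what plain hydrogen at this position would give remains open. So does the effect of an amine, a carboxylic acid or a longer chain on this carbon.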